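The source may hold more compounds than are shown below. What is called first, only, known or untested is meant among the compounds shown, and "the series" means these compounds.

Of the compounds shown here, three have so far been measured in an assay on 32D cells for inhibition of interleukin-15 (Mus musculus), read by resazurin assay, with stated times of 30 min and 2.5 days, in the presence of a further agent that is not named here (on this read-out higher numbers stand for weaker inhibition and lower numbers for stronger inhibition), and all three share one core with a dichlorophenyl amide on a sulfur-linked side chain. Compound 1 `CCOC(CCn1c(Cc2nn(C)c(=O)c3ccccc23)nnc1SCC(=O)Nc1ccc(Cl)cc1Cl)OCC` gives only a limit of the assay, > 30000 nM. Compound 2 `Cn1nc(Cc2nnc(SCCCCCCCC(=O)Nc3ccc(Cl)cc3Cl)n2CCC(=O)O)c2ccccc2c1=O`, which carries a longer chain between the sulfur and the amide and a carboxyethyl group on a different ring nitrogen, gives 23500 nM in this assay. Compound 3 `Cn1c(Cc2nn(CCC3OCCO3)c(=O)c3ccccc23)nnc1SCC(=O)Nc1ccc(Cl)cc1Cl` likewise gives only a limit, > 30000 nM. So compound 3 stands among the weakest results seen here, and the picture as a whole is thin: the limit of > 30000 nM in this assay, at which 2 of the 3 values shown sit, and the one numerical value, from compound 2, is itself very weak.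

Compound 4 `Cn1c(Cc2nn(CCC(=O)O)c(=O)c3ccccc23)nnc1SCC(=O)Nc1ccc(Cl)cc1Cl` is not yet measured. It differs from compound 3 in one place: carboxy in place of 1,3-dioxolan-2-yl on a saturated chain carbon, two bonds along the chain from an aromatic nitrogen. Among the measured compounds shown here, no measured pair in this set shows what such a swap does, so the expected size of the step is uncertain. Since compound 2, the only acid in the set, reached only 23500 nM, compound 4 is expected to remain very weak, with a step that the limit leaves unreadable from compound 3 to compound 4 that may not be resolvable at all. The estimate for compound 4 is therefore 35000 nM, within a range from 12000 nM to 100000 nM, and most likely the assay will again report only a limit.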

Compound 4, half-maximal inhibitory concentration: > 30000 nM
Compound 4: only a limit was reported (the forecaster's own chance of this, stated with the estimate: 60%); the middle value is on the limit's open side.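

Compound 3 and compound 4 both give only a limit in this assay, so no step can be read for carboxy in place of 1,3-dioxolan-2-yl. The compounds shown leave open what this swap does to inhibition, and how weak compound 3 and compound 4 really are, since most results stop at one value: the limit of > 30000 nM in this assay, at which 3 of the 4 values shown sit.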